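Shortening the Ester Tail Before a New Measurement

This account rests on a few compounds, and the source may have more. Where it says the series, first, only, none or still open, it means among the compounds named here.

Compound 1, `C=C(c1ccc(C(=O)OCCOC(=O)c2ccc(C(=O)Nc3ccc4c(c3)C(C)(C)CCC4(C)C)cc2)cc1)c1cc2c(cc1C)C(C)(C)CCC2(C)C`, gives 504000 nM in a functional assay on K562 cells (Homo sapiens) for inhibition, read by MTT assay, with a stated time of 48 h; on this read-out lower numbers stand for stronger inhibition and higher numbers for weaker inhibition. Compound 2, `CCCC(CCC)C(=O)OCCCCOC(=O)c1ccc(C(=O)Nc2ccc3c(c2)C(C)(C)CCC3(C)C)cc1`, reaches only the limit of > 1000000 nM in this assay, so no number is known for it, as recorded in the limit of > 1000000 nM in this assay, at which 1 of the 2 values shown sits. Compound 3, `CCCC(=O)OCCCOC(=O)c1ccc(C(=O)Nc2ccc3c(c2)C(C)(C)CCC3(C)C)cc1`, differs from compound 2 in one place: (propylcarbonyl)oxy in place of (((1-propylbutyl)carbonyl)oxy)methyl on a saturated chain carbon, three bonds along the chain from an oxygen next to a carbonyl group. Among the compounds with values here, no measured pair shows what this change does, so the expected step is a number no higher from compound 2 to compound 3 (the limit leaves the size open), none beyond the scatter. Compound 3 is expected to give about 1000000 nM, within a range from 300000 nM to 3000000 nM.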

Compound 3, half-maximal inhibitory concentration: 4570 nM
For compound 3 the middle estimate is 220-fold (2.34 log units) above the measured one; the measured number lies below the stated range.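

Replacing (((1-propylbutyl)carbonyl)oxy)methyl with (propylcarbonyl)oxy on this saturated chain carbon gives an at least 210-fold lower number from compound 2 to compound 3 (2.34 log units; beyond the scatter) in this assay. Within the data shown here, this place on the chain, about which no earlier pair said anything, can therefore move the read-out strongly. The value of compound 2 is a limit and not a number: the limit of > 1000000 nM in this assay, at which 1 of the 3 values shown sits.

The compounds shown do not tell which part of the larger group matters, since the whole group changes in one step. As far as these compounds go, what a carboxylic acid, an amine or a longer chain would give at this place also stays open.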